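The source may report more compounds than this note shows. Statements on the series, on what has been measured and on what is new or still open speak of the compounds shown alone.

Notes on the urea series. In a functional assay on SF-268 cells (Homo sapiens) for inhibition, read by sulforhodamine B assay, with a stated time of 48 h, tested at 10 uM (on this read-out higher numbers stand for a weaker effect at the one concentration tested and lower numbers for a stronger effect), compound 1 `O=C(Nc1cccc(-n2cc(-c3ccncc3)c(-c3cc(O)cc(Cl)c3)n2)c1)Nc1ccc(Cl)c(C(F)(F)F)c1` gives 42.1%, compound 2 `O=C(Nc1cccc(-n2cc(-c3ccncc3)c(-c3cc(O)cc(Cl)c3)n2)c1)Nc1ccc(Cl)c(Cl)c1` gives 16.2% and compound 3 `COc1cc(Cl)cc(-c2nn(-c3cccc(NC(=O)Nc4cc(C(F)(F)F)cc(C(F)(F)F)c4)c3)cc2-c2ccncc2)c1` gives 14.2%. Compound 2 thus holds the second highest of the three numbers in this assay: its nearest neighbour is compound 3, lower by a margin within the scatter, and its furthest is compound 1, higher beyond the scatter. For the measured compounds named here, the only one-place step measured so far, a number 25.9 percentage points lower from compound 1 to compound 2 (beyond the scatter), concerns chloro in place of trifluoromethyl on an aromatic carbon and does not touch the oxygen altered here.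

Compound 4 `COc1cc(Cl)cc(-c2nn(-c3cccc(NC(=O)Nc4ccc(Cl)c(Cl)c4)c3)cc2-c2ccncc2)c1` differs from compound 2 by methyl in place of hydrogen on an oxygen on an aromatic ring. Going by the values given here, no measured step shares this change. Compound 3 carries the methoxy but also a different urea aryl, and its value and that of compound 2 lie within the scatter of each other, which points to no step beyond the scatter in this assay. Compound 4 is therefore estimated at 18% (range 5% to 40%), the expected step of a number 1.8 percentage points higher from compound 2 to compound 4 (within the scatter) staying within the scatter, because compound 3 gives 14.2%.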

Compound 4, a percentage reported as activity, at one concentration (the size of the read-out at that concentration, not a potency): 25.3%
The estimate for compound 4 lay 7.3 percentage points below the measured number; measured number inside the range.
By their numbers in this assay, from the lowest: compounds 3, 2 and 4 (each within the scatter of the next, the first and the last beyond it); then compound 1.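

Read in this assay, hydroxy to methoxy on the 3-chloro-5-hydroxyphenyl group gives a number 9.1 percentage points higher from compound 2 to compound 4 (within the scatter) and is the first direct reading of a change at this oxygen. With the dichlorophenyl urea held constant, the hydrogen on this oxygen can thus be replaced by methyl without a step beyond the scatter, so this single exchange shows no need for the free hydroxy in this assay. Nothing available bears on the reason for this result.

Still open, going by these compounds, is whether a longer chain on this oxygen, such as ethoxy, or an amine in place of the hydroxy would also stay within the scatter of compound 2. Also open, on these data alone, is whether hydroxy to methoxy reads the same on the urea aryl of compound 1, which gives 42.1% in this assay with the hydroxy in place.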